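Replacing Dimethylamino with 4-Methylpiperidin-1-yl: What Compound 4 May Give

The compounds below may be only part of what the source reports. "The series", "measured", "known", "first", "only" and "open" are said of these compounds alone.

Compound 1 `CC1CCN(Cc2ccc3nc(NC(=O)N/N=C/c4cn(Cc5ccccc5Cl)c5ccccc45)sc3c2)CC1`: 1080 nM
Compound 2 `Cc1ccc(Cn2cc(/C=N/NC(=O)Nc3nc4ccc(CN5CCC(C)CC5)cc4s3)c3ccccc32)cc1`: 410 nM
Compound 3 `CN(C)Cc1ccc2nc(NC(=O)N/N=C/c3cn(Cc4ccc(Cl)cc4)c4ccccc34)sc2c1`: 290 nM

In a functional assay on NCI-H460 cells (Homo sapiens) for cytotoxicity, read by MTT assay, with a stated time of 72 h (a higher number here means a weaker inhibitor, a lower number a stronger inhibitor), compound 3 gives 290 nM, the lowest of the three numbers: it sits within the scatter of compound 2 and beyond the scatter of compound 1. Compound 4 `CC1CCN(Cc2ccc3nc(NC(=O)N/N=C/c4cn(Cc5ccc(Cl)cc5)c5ccccc45)sc3c2)CC1` keeps the 4-chlorophenyl of compound 3 and differs only in the amine: 4-methylpiperidin-1-yl in place of dimethylamino on a saturated chain carbon bound to an aromatic carbon. Going by the values given here, the single measured step, a 2.6-fold lower number from compound 1 to compound 2 (0.42 log units; beyond the scatter), concerns the group on the saturated chain carbon bound to an aromatic nitrogen, not the amine, so it does not bear on this change. On these data alone, compounds 1 and 2 carry the 4-methylpiperidin-1-yl group and give numbers that, against compound 3, range from within the scatter to beyond it, yet each also differs from compound 3 elsewhere, so the amine exchange on its own is untested here. The step of a 1.4-fold higher number from compound 3 to compound 4 (0.14 log units; within the scatter) is therefore expected to stay within the scatter, leaning if anything toward a higher number. Compound 4 is estimated at 400 nM, with a range from 150 nM to 1100 nM.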

Compound 4, half-maximal inhibitory concentration: 400 nM
Compound 4: middle estimate and measured number agree at the digits printed, within the range that was stated.
By their numbers in this assay, from the lowest: compounds 3, 4 and 2 (each within the scatter of the next); then compound 1.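

In this assay, the exchange of dimethylamino for 4-methylpiperidin-1-yl on a saturated chain carbon bound to an aromatic carbon can now be read directly (a 1.4-fold higher number from compound 3 to compound 4 (0.14 log units; within the scatter)), and with the 4-chlorophenyl held fixed the two amines cannot be told apart. With the 4-methylpiperidin-1-yl held fixed, chloro in place of methyl on an aromatic carbon gives a 1.0-fold lower number from compound 2 to compound 4 (0.01 log units; within the scatter) and likewise separates nothing. Only the 2-chlorophenyl of compound 1 stands apart from compounds 2 and 4: 4-chlorophenyl in its place gives a 2.7-fold lower number from compound 1 to compound 4 (0.43 log units; beyond the scatter) on the same footing as a 2.6-fold lower number from compound 1 to compound 2 (0.42 log units; beyond the scatter) for the 4-methylphenyl group. No measurement shown explains these results. On these data alone, whether morpholin-4-yl, an unsubstituted piperidin-1-yl or a carboxylic acid on the same saturated chain carbon would stay within the scatter of these numbers remains open.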